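A few compounds are considered here, and "the series" means these few. Any claim that something is new, unique, unknown or untested is made for them only; others in the source may bear on it.

Measured so far:
Compound 1, `COc1ccc(OCCCCCN2CCCC(COC(=O)c3ccccc3N3C(=O)CC(C)C3=O)C2)cc1`, gives 14500 nM.
Compound 2, `O=C(OCC1CCCNC1)c1ccccc1-c1ccccc1`, gives 7080 nM.

Both numbers come from an in vitro functional assay on HEK ts201 cells for antagonist activity at Neuronal acetylcholine receptor; alpha4/beta2 (Homo sapiens), read by fluorescence and calcium flux; on this read-out lower numbers stand for stronger inhibition and higher numbers for weaker inhibition. Of the two compounds measured there, compound 1 stands at the higher number; the number for compound 2 lies lower, by a gap wider than the usual scatter of repeated measurements. Within the data shown here, no single-change step connects these two measured compounds, so no measured step is available to guide the next change.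

The piece follows compound 1 to compound 3, `COc1ccc(OCCCCCN2CCCC(COC(=O)c3ccccc3N3C(=O)CC(C)C3=O)C2)cc1OC`, which has not yet been measured in this assay. The change is methoxy in place of hydrogen on an aromatic carbon. The entering group is small and sits on a six-membered aromatic ring of carbon only, ortho to a methoxy group that is already there. With no measured step of this kind among the compounds shown, there is no basis for expecting a large shift. The estimate for compound 3 is therefore close to compound 1, a step of a 1.0-fold lower number from compound 1 to compound 3 (0.02 log units; within the scatter) that is expected to stay within the scatter. In this assay compound 3 is expected to give 14000 nM, most likely between 5000 nM and 40000 nM.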

Compound 3, half-maximal inhibitory concentration: 8320 nM
Compound 3: middle estimate off by 1.7-fold (0.23 log units), on the high side; the measured number falls inside the stated range.
By their numbers in this assay, from the lowest: compounds 2, 3 and 1 (each within the scatter of the next, the first and the last beyond it).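

In this assay, among these compounds, the change from the 4-methoxyphenoxy group of compound 1 to the 3,4-dimethoxyphenoxy group of compound 3 gives a 1.7-fold lower number from compound 1 to compound 3 (0.24 log units; within the scatter), and this is the first measured step of its kind. It shows that a methoxy group can enter on this aromatic carbon, ortho to the methoxy group already there, with no change in the number that can be told apart from the variation between repeated measurements. Nothing measured here accounts for this outcome.

A single step at a single position cannot show whether other groups on the same carbon, such as a hydroxyl group, a chlorine atom or an ethoxy group, would leave the number just as undisturbed. It also leaves open whether a methoxy group on a different carbon of this ring would do the same, and whether a shorter chain between the ring and the rest of the molecule would change the outcome of this step.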